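Swapping a fluorophenyl for a methylaminophenyl: expected lipophilicity

This account rests on a few compounds, and the source may have more. Where it says the series, first, only, none or still open, it means among the compounds named here.

Measured so far:
Compound 1, `CC[C@H](Nc1c(C#N)c(-c2ccc(Br)cc2)nc2cnccc12)C(N)=O`, in a physicochemical assay for lipophilicity, read by HPLC, at pH 7.5 (on this read-out higher numbers stand for higher lipophilicity and lower numbers for lower lipophilicity), gives 2.3.
Compound 2, `CC[C@@H](Nc1c(C#N)c(-c2ccc(-c3ccc(F)cc3)cc2)nc2cnccc12)C(N)=O`, in this assay gives 2.7.
Compound 3, `CCOc1ccccc1-c1ccc(-c2nc3cnccc3c(N[C@H](CC)C(=O)NS(C)(=O)=O)c2C#N)cc1`, in this assay gives 2.2.

Compound 2 stands highest of the three; compound 1 is nearest and compound 3 furthest, and both gaps lie beyond the scatter. Compound 4, `CC[C@@H](Nc1c(C#N)c(-c2ccc(-c3ccccc3NC)cc2)nc2cnccc12)C(N)=O`, differs from compound 2 in one place: 2-(methylamino)phenyl in place of 4-fluorophenyl on an aromatic carbon. The entering group brings a hydrogen-bond donor and a hydrogen-bond acceptor, where the leaving group had none, so a downward step in this assay beyond the scatter is expected. The expected step of a number 0.50 log units lower from compound 2 to compound 4 (beyond the scatter) is a drop. Compound 4 is estimated at 2.2, with a range from 1.8 to 2.6.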

Compound 4, distribution coefficient: 2.5
Beside the measured number, compound 4's estimate is 0.30 log units below it; measured number inside the range.
By their numbers in this assay, from the lowest: compounds 3, 1, 4 and 2 (each within the scatter of the next, the first and the last beyond it).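

Among these compounds, compound 2 and compound 4 form the first pair here that differs in one place, so this position can now be read directly. In this assay replacing 4-fluorophenyl with 2-(methylamino)phenyl gives a number 0.20 log units lower from compound 2 to compound 4 (within the scatter) even though the entering group carries a hydrogen-bond donor and a hydrogen-bond acceptor and the leaving group carries neither. A single pair shows this for one swap only. As far as these compounds go, whether a phenyl bearing a carboxylic acid or a dimethylamino group would also stay within the scatter remains open. Nothing shown explains the size of this step.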